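The compounds below may be only part of what the source reports. "The series", "measured", "known", "first", "only" and "open" are said of these compounds alone.

Measured so far:
compound 1, `C#CCCCn1c(Cc2cc(OC)c(OC)c(OC)c2)nc2c(N)ncnc21`, 24000 nM;
compound 2, `CC/C=C/Cn1c(Cc2cc(OC)c(OC)c(OC)c2)nc2c(N)ncnc21`, 46800 nM;
compound 3, `COCCn1c(Cc2cc(OC)c(OC)c(OC)c2)nc2c(N)ncnc21`, 64600 nM.

In a functional assay on MCF7 cells (Homo sapiens) for antiproliferative activity (on this read-out lower numbers stand for stronger inhibition and higher numbers for weaker inhibition), compound 3 gives the highest number of the three: a 2.7-fold higher number from compound 1 to compound 3 (0.43 log units; beyond the scatter), while a 1.4-fold higher number from compound 2 to compound 3 (0.14 log units; within the scatter). Compound 4, `COc1cc(Cc2nc3c(N)ncnc3n2C)cc(OC)c1OC`, differs from compound 3 by hydrogen in place of methoxymethyl on a saturated chain carbon bound to an aromatic nitrogen. Within the data shown here, no measured step removes the whole side chain, so the nearest guides are the swaps within it: a 2.0-fold higher number from compound 1 to compound 2 (0.29 log units; within the scatter) and a 2.7-fold higher number from compound 1 to compound 3 (0.43 log units; beyond the scatter), both small. A step of similar modest size is therefore expected, if anything toward a higher number, so the estimate for compound 4 is 80000 nM, between 30000 nM and 200000 nM, meaning a 1.2-fold higher number from compound 3 to compound 4 (0.09 log units; within the scatter).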

Compound 4, half-maximal inhibitory concentration: 70800 nM
Compound 4: the middle estimate sits 1.1-fold (0.05 log units) above what was measured; the measured number falls inside the stated range.
By their numbers in this assay, from the lowest: compounds 1, 2, 3 and 4 (each within the scatter of the next, the first and the last beyond it).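

Cutting 2-methoxyethyl back to methyl gives a 1.1-fold higher number from compound 3 to compound 4 (0.04 log units; within the scatter) in this assay and putting hydrogen in place of but-1-en-1-yl gives a 1.5-fold higher number from compound 2 to compound 4 (0.18 log units; within the scatter) so neither of these side chains can be told apart from plain methyl. Only the but-3-yn-1-yl chain stands apart, with a 3.0-fold higher number from compound 1 to compound 4 (0.47 log units; beyond the scatter) and that step is modest. Nothing available explains this difference.

On these data alone, whether an amine, a carboxylic acid or a longer chain ending in a phenyl ring would shift the number further from that of compound 4 remains open.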